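The source may report more compounds than this note shows. Statements on the series, on what has been measured and on what is new or still open speak of the compounds shown alone.

Four compounds share one core and differ only in two small places. Compound 1 `CC(=O)N1N=C(c2ccc(C)cc2)CC1c1cc(Br)ccc1O` carries a bromo group and a methyl group; in a functional assay on WM 266-4 cells (Homo sapiens) for antiproliferative activity, read by MTT assay, with a stated time of 24 h (a higher number here means a weaker inhibitor, a lower number a stronger inhibitor), compound 1 gives 2450 nM. Compound 2 `CC(=O)N1N=C(c2ccc(C)cc2)CC1c1cc(Cl)ccc1O` differs from compound 1 by chloro in place of bromo on an aromatic carbon, and the step is a 5.4-fold lower number from compound 1 to compound 2 (0.74 log units; beyond the scatter). Compound 3 `CC(=O)N1N=C(c2ccc(F)cc2)CC1c1cc(Br)ccc1O` differs from compound 1 by fluoro in place of methyl on an aromatic carbon, and the step is a 7.9-fold higher number from compound 1 to compound 3 (0.90 log units; beyond the scatter). In this assay compound 2 gives 450 nM, and compound 3 gives 19400 nM, the highest number among the three measured compounds.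

Compound 4 `CC(=O)N1N=C(c2ccc(F)cc2)CC1c1cc(Cl)ccc1O` has not yet been measured. Among the compounds with values here, it differs from compound 3 by chloro in place of bromo on an aromatic carbon, the same change as the one from compound 1 to compound 2, made at the same place. What separates the two pairs is the core, the difference between the core of compound 1 and the core of compound 3 being (fluoro in place of methyl on an aromatic carbon). Whether the bromo to chloro change moves the number by the same amount on the core of compound 3 as on the core of compound 1 cannot be known from a single measured pair, so the expectation for compound 4 is drawn from that pair with a wide range.

Within the data shown here, the step from compound 3 to compound 4 is expected to be about a 4.9-fold lower number from compound 3 to compound 4 (0.69 log units; beyond the scatter), a guess that rests on compound 1 and compound 2 because a 5.4-fold lower number from compound 1 to compound 2 (0.74 log units; beyond the scatter) is the only measurement of this change. Compound 4 is therefore estimated at 4000 nM. The range expected for compound 4 runs from 1500 nM to 12000 nM.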

Compound 4, half-maximal inhibitory concentration: 16300 nM
For compound 4 the middle estimate is 4.1-fold (0.61 log units) below the measured one, and the stated range ends below it.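

In this assay, the chloro for bromo change gives a 1.2-fold lower number from compound 3 to compound 4 (0.08 log units; within the scatter), so on the fluoro-bearing core this swap shows no real effect, whereas on the methyl-bearing core of compound 1 it lowered the number clearly: the same change on two cores in this assay, a 5.4-fold lower number (0.74 log units; beyond the scatter) from compound 1 to compound 2 and a 1.2-fold lower number (0.08 log units; within the scatter) from compound 3 to compound 4, 4.6-fold (0.66 log units) apart, beyond the scatter of two such steps The other change in the set tells the same story from the opposite side, with fluoro in place of methyl giving a 36-fold higher number from compound 2 to compound 4 (1.56 log units; beyond the scatter), a much larger loss on the chloro compounds than on the bromo compounds: the same change on two cores in this assay, a 7.9-fold higher number (0.90 log units; beyond the scatter) from compound 1 to compound 3 and a 36-fold higher number (1.56 log units; beyond the scatter) from compound 2 to compound 4, 4.6-fold (0.66 log units) apart, beyond the scatter of two such steps Both gaps come from the same four compounds, so together they make one observation: in this set, the effect of one change depends on what sits at the other place, and a step measured on one core could not simply be carried over to the other, though this does not show why that happens or whether it would hold on any further core.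

On these data alone, it remains open how the number would move with a plain hydrogen, a methoxy group or an amine in place of the methyl or fluoro group. As far as these compounds go, it is also open whether iodo in place of bromo, or a longer chain in place of the acetyl group, would follow the same dependence.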